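A few compounds are considered here, and "the series" means these few. Any claim that something is new, unique, unknown or untested is made for them only; others in the source may bear on it.

Going by the values given here, compound 1 `Cc1c(CCCC(=O)O)c2cccc(/C=C/c3ccc(OCCCCc4c(F)c(F)cc(F)c4F)cc3)c2n1CC(=O)O` is the only member of the series with a numerical read-out in a physicochemical assay for permeability, using PAMPA, with a stated time of 4 h, at pH 7.4, tested at 50 uM; on this read-out lower numbers stand for lower permeability and higher numbers for higher permeability; in that assay compound 1 gives 0.5 10^-6 cm/s. Compound 2 `Cc1c(F)cccc1CCCCOc1ccc(/C=C/c2cccc3c(CCCC(=O)O)cn(CC(=O)O)c23)cc1` is reported in this assay only as a limit of the assay, < 0.05 10^-6 cm/s, which is the limit of < 0.05 10^-6 cm/s in this assay, at which 1 of the 2 values shown sits. Compound 3 `Cc1c(CCCC(=O)O)c2cccc(/C=C/c3ccc(OCCCCc4cc(F)c(F)c(F)c4F)cc3)c2n1CC(=O)O` is not yet measured. It differs from compound 1 in one place: 2,3,4,5-tetrafluorophenyl in place of 2,3,5,6-tetrafluorophenyl on a saturated chain carbon, four bonds along the chain from an oxygen on an aromatic ring. Among the compounds with values here, no measured step of this kind stands, so the expected step is no change at the digits printed from compound 1 to compound 3 (within the scatter), no larger than the usual scatter in either direction. Compound 3 is accordingly expected to give 0.5 10^-6 cm/s in this assay, within the range 0.2 10^-6 cm/s to 1.2 10^-6 cm/s.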

Compound 3, apparent permeability: 0.3 10^-6 cm/s
Compound 3: middle estimate off by 1.7-fold (0.22 log units), on the high side; the measured number falls inside the stated range.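

In this assay, going by these compounds alone, 2,3,4,5-tetrafluorophenyl in place of 2,3,5,6-tetrafluorophenyl gives the first readable step at this position, on a saturated chain carbon, four bonds along the chain from an oxygen on an aromatic ring: a 1.7-fold lower number from compound 1 to compound 3 (0.22 log units; within the scatter). Rearranging the four fluorines on this ring therefore moves the read-out by no more than the scatter. Compound 2 remains a limit of the assay and enters no step: the limit of < 0.05 10^-6 cm/s in this assay, at which 1 of the 3 values shown sits.

As far as these compounds go, whether an unsubstituted phenyl or a longer chain at this place would hold the read-out remains open. So does the effect of replacing either carboxylic acid with an amide.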